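Tetrazole for Thiadiazole on a Thioether Sulfur

The source may report more compounds than this note shows. Statements on the series, on what has been measured and on what is new or still open speak of the compounds shown alone.

Among the measured compounds shown here, compound 2 `Cc1nnc(SCC(=O)N/N=c2/scc(-c3ccc(Cl)cc3)n2-c2ccccc2)s1` is the only compound with a number in a functional assay on C6 cells (Rattus norvegicus) for cytotoxicity, read by MTT assay, with a stated time of 24 h (a lower number here means a stronger inhibitor, a higher number a weaker inhibitor), where compound 2 gives 28 ug/mL. Compound 1 `Cc1nnc(SCC(=O)N/N=c2/scc(-c3ccc([N+](=O)[O-])cc3)n2-c2ccccc2)s1` stands in this assay as "not determined" (no result reported), so no result is reported for it. Compound 3 `O=C(CSc1nnnn1-c1ccccc1)N/N=c1/scc(-c2ccc(Cl)cc2)n1-c1ccccc1` differs by 1-phenyl-1H-tetrazol-5-yl in place of 5-methyl-1,3,4-thiadiazol-2-yl on a sulfur. For the measured compounds named here, no pair of measured compounds shows what such a change does, so the step from compound 2 to compound 3 in this assay is expected to be no change at the digits printed from compound 2 to compound 3 (within the scatter), no further than the scatter. Compound 3 is therefore estimated at 28 ug/mL, within 12 ug/mL to 65 ug/mL.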

Compound 3, half-maximal inhibitory concentration: > 200 ug/mL
Compound 3 gave a limit, no number (the forecaster's own chance of this, stated with the estimate: 10%); middle value at least 7.1-fold (0.85 log units) from the limit.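

In this assay, the group on the thioether sulfur proves not to be freely exchangeable: 1-phenyl-1H-tetrazol-5-yl in place of 5-methyl-1,3,4-thiadiazol-2-yl gives an at least 7.1-fold higher number from compound 2 to compound 3 (0.85 log units; beyond the scatter). Among the compounds shown here, this is the first step that can be read at this position. Its full size stays unknown, because compound 3 gives a limit and not a number: the limit of > 200 ug/mL in this assay, at which 1 of the 3 values shown sits.

The tetrazole ring and its phenyl group enter together, so the compounds shown do not separate the two. They also leave open how 1-methyl-1H-tetrazol-5-yl or an unsubstituted phenyl on the sulfur would read.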